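A few compounds are considered here, and "the series" means these few. Any claim that something is new, unique, unknown or untested is made for them only; others in the source may bear on it.

In a functional assay on K562 cells (Homo sapiens) for cytotoxicity, read by ELISA, with a stated time of 4 days (on this read-out lower numbers stand for stronger inhibition and higher numbers for weaker inhibition), compound 1 (`Clc1ccc(-c2cc(-c3ccco3)cc(-c3ccc(Cl)s3)n2)cc1`) gives 10500 nM, compound 2 (`Cc1ccc(-c2cc(-c3ccoc3)cc(-c3ccc(Cl)s3)n2)o1`) gives 12700 nM and compound 3 (`Cc1cccc(-c2cc(-c3ccoc3)cc(-c3ccc(Cl)s3)n2)c1`) gives 13700 nM. These three numbers lie within the usual scatter of repeated measurements, so compound 3 stands level with the other two and no ranking can be drawn among them.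

The next structure is compound 4 (`Clc1ccc(-c2cc(-c3ccoc3)cc(-c3ccc(Cl)s3)n2)cc1`). It has 4-chlorophenyl in place of 3-methylphenyl on an aromatic carbon, next to the ring nitrogen of the six-membered aromatic ring: 4-chlorophenyl in place of 3-methylphenyl on an aromatic carbon.

Among the compounds with values here, only one measured step changes a group at this same place, and it is a 1.1-fold higher number from compound 2 to compound 3 (0.03 log units; within the scatter). That exchange of 5-methylfuran-2-yl for 3-methylphenyl left the number within the scatter. Compound 1 offers a second clue, since it also carries the 4-chlorophenyl group and gives 10500 nM. Within the data shown here, three compounds are a thin basis, and no measured step yet shows what 4-chlorophenyl does when paired with the furan-3-yl group. Even so, nothing here points to a large shift in this assay, so no change beyond the scatter is expected.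

The expected step is a 1.2-fold lower number from compound 3 to compound 4 (0.08 log units; within the scatter). For compound 4 the estimated value is 11500 nM, with an expected range from 6000 nM to 22000 nM.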

Compound 4, half-maximal inhibitory concentration: 19600 nM
Beside the measured number, compound 4's estimate is 1.7-fold (0.23 log units) below it; measured number inside the range.
By their numbers in this assay, from the lowest: compounds 1, 2, 3 and 4 (each within the scatter of the next).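

At this position, on an aromatic carbon next to the ring nitrogen, the results now cover three different groups: 3-methylphenyl, 5-methylfuran-2-yl and 4-chlorophenyl. In this assay, neither exchange leading to 4-chlorophenyl moves the number beyond the scatter, whether it replaces 3-methylphenyl (a 1.4-fold higher number from compound 3 to compound 4 (0.16 log units; within the scatter)) or 5-methylfuran-2-yl (a 1.5-fold higher number from compound 2 to compound 4 (0.19 log units; within the scatter)), so this position tolerates a chlorine on the phenyl ring as well as these other aromatic groups, with no ranking among them. Compounds 1 and 4 add a comparison at a different place, where furan-3-yl stands in place of furan-2-yl, and this exchange also stays within the scatter (a 1.9-fold higher number from compound 1 to compound 4 (0.27 log units; within the scatter)). No measurement here offers an explanation for these results.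

Going by these compounds, every group seen at this position is an aromatic ring, so it remains open whether something of another kind, such as an amine, a carboxylic acid or a longer carbon chain, would shift the number beyond the scatter. The 5-chlorothiophen-2-yl group is the same in all of these compounds, so its contribution also remains unknown.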